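Nitrophenyl in Place of Fluorophenyl on an Inactive Hydrazone Core

The compounds below may be only part of what the source reports. "The series", "measured", "known", "first", "only" and "open" are said of these compounds alone.

Compound 1 `CC(/C=N/Nc1ccc([N+](=O)[O-])cc1)=N\NC(=O)c1ccccc1F` carries a 2-fluorophenyl group on its carbonyl carbon. In a functional assay on cells (Splenocyte, Mus musculus, strain BALB/c) for inhibition, read by scintillation counting and thymidine incorporation, with a stated time of 72 h (a higher number here means a weaker inhibitor, a lower number a stronger inhibitor), compound 1 gives > 12000 nM, which is a limit of the assay and not a number. Compound 2 `CC(/C=N/Nc1ccc([N+](=O)[O-])cc1)=N\NC(=O)c1ccccc1Oc1ccccc1` gives > 12000 nM in this assay, again only a limit. Compound 3 `CC(/C=N/N(C)c1ccc([N+](=O)[O-])cc1)=N\NC(=O)c1ccc(N)cc1` gives > 12000 nM in this assay, also a limit. Compound 1 therefore stands exactly where the whole measured set stands, namely at the limit of > 12000 nM in this assay, at which 3 of the 3 values shown sit.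

Going by the values given here, the only measured step, a step that the two limits leave unreadable from compound 1 to compound 2, has no readable size, since both of its values are limits. Compound 4 `CC(/C=N/Nc1ccc([N+](=O)[O-])cc1)=N\NC(=O)c1ccc([N+](=O)[O-])cc1` differs from compound 1 in a single place: 4-nitrophenyl in place of 2-fluorophenyl on a carbonyl carbon. Among the compounds with values here, no measured step with a readable size bears on this change, so no direction can be read from the data. Compound 4 is expected to remain at the limit because of the limit of > 12000 nM in this assay, at which 3 of the 3 values shown sit. The step from compound 1 to compound 4 is estimated as a step that the limit leaves unreadable from compound 1 to compound 4, meaning no change beyond the scatter. For compound 4 the estimate is 20000 nM, with a range from 8000 nM to 60000 nM.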

Compound 4, half-maximal inhibitory concentration: 980 nM
Beside the measured number, compound 4's estimate is 20-fold (1.31 log units) above it; measured number below the stated range.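

In this assay, the group on the carbonyl carbon clearly matters, which the three earlier compounds, all stuck at one limit, could not show. Placing 4-nitrophenyl instead of 2-fluorophenyl on this carbon gives an at least 12-fold lower number from compound 1 to compound 4 (1.08 log units; beyond the scatter), so the shared core can carry measurable inhibition when the right group sits there. Compound 4 is the only compound shown with a number and not a limit, which gives later changes a value that can be compared: the limit of > 12000 nM in this assay, at which 3 of the 4 values shown sit.

This single step changes both the substituent and its ring number, so it cannot say which of the two matters, and 4-fluorophenyl or 2-nitrophenyl would separate them. As far as these compounds go, it also remains open whether a nitrile or a carboxylic acid in place of the nitro group would keep a measurable value in this assay.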